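From compound 3 to compound 4: one group exchanged

The compounds below may be only part of what the source reports. "The series", "measured", "known", "first", "only" and "open" are said of these compounds alone.

Measured so far in an in vivo ADME assay on the whole organism (strain 129/SvEvBrd x C57BL/6) for pharmacokinetics, with Mus musculus as the target (a higher number here means that a larger share of the oral dose reaches the circulation, a lower number that a smaller share of the oral dose reaches the circulation), are three compounds.
- Compound 1 (`CCc1[nH]c(C(C)=O)nc1[C@@H](O)[C@H](O)[C@H](O)CO`) gives 17.1%
- Compound 2 (`CC(O)c1nc([C@@H](O)[C@H](O)[C@H](O)CO)c[nH]1`) gives 22%
- Compound 3 (`Cc1nc(-c2nc([C@@H](O)[C@H](O)[C@H](O)CO)c[nH]2)cs1`) gives 23%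

Compound 3 stands within the usual scatter of both compound 1 and compound 2, so the three do not separate. Compound 4 (`OC[C@@H](O)[C@@H](O)[C@H](O)c1c[nH]c(-c2ncc[nH]2)n1`) differs from compound 3 in one group (1H-imidazol-2-yl in place of 2-methyl-1,3-thiazol-4-yl on an aromatic carbon) and carries 1H-imidazol-2-yl in place of 2-methyl-1,3-thiazol-4-yl. Going by the values given here, only one measured step touches this place (a number 1 percentage points higher from compound 2 to compound 3 (within the scatter)). It exchanges a different group and is small. No step beyond the scatter is therefore expected in this assay, and the data favour no direction. Expected is only a small shift (a number 1 percentage points lower from compound 3 to compound 4 (within the scatter)). The expected value for compound 4 is 22% within an estimated range (10% to 36%).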

Compound 4, oral bioavailability: 28%
Compound 4: the middle estimate sits 6 percentage points below what was measured; low and high end bracket the measured number.
By their numbers in this assay, from the lowest: compounds 1, 2, 3 and 4 (each within the scatter of the next, the first and the last beyond it).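

At this aromatic carbon, a number 5 percentage points higher from compound 3 to compound 4 (within the scatter) in this assay comes with 1H-imidazol-2-yl replacing 2-methyl-1,3-thiazol-4-yl, and a number 6 percentage points higher from compound 2 to compound 4 (within the scatter) in this assay comes with 1H-imidazol-2-yl replacing 1-hydroxyethyl. Neither step separates the compounds, so these three differently built groups are not told apart here, even though only 1H-imidazol-2-yl brings a ring hydrogen-bond donor. Nothing available explains these numbers. Still open, going by these compounds, is whether an amine or a carboxylic acid on this carbon would give a step beyond the scatter.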